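Predicting the Cytotoxicity of Compound 3 from Two Analogues

This account rests on a few compounds, and the source may have more. Where it says the series, first, only, none or still open, it means among the compounds named here.

Among the measured compounds shown here, the series so far rests on two measured compounds. Compound 1 `COc1cc(NC(C)CCCNC(=O)NNC(=O)/C=C/c2ccc(Cl)cc2)c2ncccc2c1` gives 7300 nM in an ADME assay on L6 cells (Rattus norvegicus) for cytotoxicity, read by resazurin assay, with a stated time of 70 h (on this read-out lower numbers stand for stronger inhibition and higher numbers for weaker inhibition), while compound 2 `COc1cc(NC(C)CCCNC(=O)NNC(=O)/C=C/c2ccc(C(F)(F)F)cc2)c2ncccc2c1` gives 28300 nM. For the measured compounds named here, the single step between them, a 3.9-fold higher number from compound 1 to compound 2 (0.59 log units; beyond the scatter), leaves compound 2 standing as the higher of the two numbers and thus as the weaker of the pair on this read-out.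

Compound 3 `COc1cc(NC(C)CCCNC(=O)NNC(=O)Nc2ccc(Cl)cc2)c2ncccc2c1` differs from compound 2 in one place: (4-chlorophenyl)amino in place of 2-(4-(trifluoromethyl)phenyl)ethenyl on a carbonyl carbon. This change brings back the chloro substituent that compound 1 carries and at the same time alters the attachment to the carbonyl carbon, so the measured step bears on it only in part. Going by the values given here, because a 3.9-fold higher number from compound 1 to compound 2 (0.59 log units; beyond the scatter) was modest, the return to chloro is expected to move the number back toward that of compound 1, whereas the amino in place of the ethenyl is covered by no measured pair and adds uncertainty. Compound 3 is therefore expected to show a step of a 2.4-fold lower number from compound 2 to compound 3 (0.37 log units; beyond the scatter). The estimate for compound 3 is 12000 nM, with a range from 3500 nM to 40000 nM.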

Compound 3, half-maximal inhibitory concentration: 91900 nM
For compound 3 the middle estimate is 7.7-fold (0.88 log units) below the measured one; measured number above the stated range.
By their numbers in this assay, from the lowest: compound 1; then compound 2; then compound 3.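

In this assay, the pair that keeps the chloro substituent shows a 13-fold higher number from compound 1 to compound 3 (1.10 log units; beyond the scatter), a large step that comes from (4-chlorophenyl)amino in place of 2-(4-chlorophenyl)ethenyl on a carbonyl carbon, a change that the earlier pair of compounds did not touch. This step is large, whereas the exchange of chloro for trifluoromethyl on the aromatic carbon was modest, so among these compounds the change at the carbonyl carbon gives the bigger move. The further change from the trifluoromethyl compound gives a 3.2-fold higher number from compound 2 to compound 3 (0.51 log units; beyond the scatter), so the number moves past that of compound 2 instead of returning toward that of compound 1, and compound 3 has the highest number of the three, which marks it as the weakest on this read-out.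

The data given here offer nothing that bears on the cause of this shift. The compounds shown leave open how the number would respond to trifluoromethyl on the ring of the (4-chlorophenyl)amino group, or to a methylene group or an oxygen atom in place of its amino nitrogen.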